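The source may report more compounds than this note shows. Statements on the series, on what has been measured and on what is new or still open speak of the compounds shown alone.

Working notes on the series, read in a functional assay on HT-29 cells (Homo sapiens) for inhibition, read by CCK-8 assay, with a stated time of 24 h; on this read-out higher numbers stand for weaker inhibition and lower numbers for stronger inhibition. Compound 1 `O=C1Nc2ccccc2/C1=C/c1ccc(-c2cn(-c3ccc(F)cc3)nn2)cc1` gives 17700 nM, and compound 2 `N#Cc1ccccc1-n1cc(-c2ccc(/C=C3\C(=O)Nc4ccccc43)cc2)nn1` gives 14400 nM. Only these two numbers are available, and compound 2 stands within the scatter of compound 1.

The next structure is compound 3 `N#Cc1cccc(-n2cc(-c3ccc(/C=C4\C(=O)Nc5ccccc54)cc3)nn2)c1`. The change is 3-cyanophenyl in place of 2-cyanophenyl on an aromatic nitrogen, with the same atoms joined differently.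

Within the data shown here, one measured step bears on this: a 1.2-fold lower number from compound 1 to compound 2 (0.09 log units; within the scatter), where 2-cyanophenyl replaces 4-fluorophenyl on an aromatic nitrogen. That single exchange stays within the scatter. Among the measured compounds shown here, it is thin evidence, and no measured pair shows what moving the nitrile alone does. Given the size of the step of a 1.2-fold lower number from compound 1 to compound 2 (0.09 log units; within the scatter), no step beyond the scatter is expected in this assay, and neither direction is favoured. The estimated step is a 1.0-fold lower number from compound 2 to compound 3 (0.01 log units; within the scatter). For compound 3 the expected value is 14000 nM, with an estimated range from 6000 nM to 30000 nM.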

Compound 3, half-maximal inhibitory concentration: > 20000 nM
Compound 3: a limit, no number; the forecaster's own chance of this, stated with the estimate: 8%; middle value at least 1.4-fold (0.15 log units) from the limit.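

Compound 3 reaches a limit of the assay and not a number: the limit of > 20000 nM in this assay, at which 1 of the 3 values shown sits. In this assay, moving the nitrile gives an at least 1.3-fold higher number from compound 2 to compound 3 (0.14 log units; that floor lies within the scatter), while the comparison with the fluorinated ring gives an at least 1.1-fold higher number from compound 1 to compound 3 (0.05 log units; that floor lies within the scatter). Unlike the step from compound 1 to compound 2, which has a measured size, these two steps have only a floor, so this position on the aromatic nitrogen is not yet shown to matter, but a large loss on going to 3-cyanophenyl is not excluded either.

As far as these compounds go, how far the true value of compound 3 lies from its limit remains open, and with it the real size of both steps. The compounds shown also leave open whether 4-cyanophenyl would read like compound 2 or like compound 3, and how a phenyl ring carrying an amine or a carboxylic acid in place of the nitrile would read on the same aromatic nitrogen.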